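The source may hold more compounds than are shown below. What is called first, only, known or untested is meant among the compounds shown, and "the series" means these compounds.

Of the compounds shown here, three on the shared core have been measured in a functional assay on U-937 cells (Homo sapiens) for cytotoxicity, read by MTT assay, with a stated time of 24 h; a lower number here means a stronger inhibitor, a higher number a weaker inhibitor. Compound 1 `CCCc1cc2ccccc2nc1-c1cn(-c2ccc(F)cc2)nn1` gives 67.4 ug/mL. Compound 3 `CCCCc1cc2ccccc2nc1-c1cn(-c2ccc(F)cc2)nn1` gives 66.2 ug/mL. Compound 2 `CCc1cc2ccccc2nc1-c1cn(CCC(F)(F)C(F)(F)C(F)(F)C(F)(F)C(F)(F)C(F)(F)C(F)(F)C(F)(F)F)nn1` gives 55.9 ug/mL; the difference between the core of compound 2 and the core of compound 1 is not broken down here. From compound 1 to compound 3 the change is methyl in place of hydrogen on a saturated chain carbon, three bonds along the chain from an aromatic carbon and the step is a 1.0-fold lower number from compound 1 to compound 3 (0.01 log units; within the scatter). Compound 4 `CCCc1cc2ccccc2nc1-c1cn(CCC(F)(F)C(F)(F)C(F)(F)C(F)(F)C(F)(F)C(F)(F)C(F)(F)C(F)(F)F)nn1` is the unmeasured partner of compound 2, differing by methyl in place of hydrogen on a saturated chain carbon, two bonds along the chain from an aromatic carbon; this is the same kind of change as before, but its place is on a saturated chain carbon two bonds along the chain from an aromatic carbon rather than three. Because the earlier step of a 1.0-fold lower number from compound 1 to compound 3 (0.01 log units; within the scatter) lies within the scatter, the step from compound 2 to compound 4 is expected to be a 1.0-fold lower number from compound 2 to compound 4 (0.01 log units; within the scatter). Compound 4 is therefore estimated at 55 ug/mL, with a likely range from 35 ug/mL to 90 ug/mL.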

Compound 4, half-maximal inhibitory concentration: > 100 ug/mL
Compound 4: only a limit was reported; the forecaster's own chance of this, stated with the estimate: 5%; at least 1.8-fold (0.25 log units) between middle value and limit.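

In this assay compound 4 gives > 100 ug/mL, which is a limit of the assay and not a number. The new step is therefore known only by its floor: an at least 1.7-fold higher number from compound 2 to compound 4 (0.25 log units; that floor lies within the scatter). Whether methyl in place of hydrogen carries from one core to the other, with its place here two bonds along the chain from an aromatic carbon rather than three, is neither shown nor ruled out: the same change on two cores in this assay, a 1.0-fold lower number (0.01 log units; within the scatter) from compound 1 to compound 3 and an at least 1.7-fold higher number (0.25 log units; that floor lies within the scatter) from compound 2 to compound 4; the limit leaves it open whether they differ

Open, from the compounds shown here alone, is how far the step from the ethyl chain to the propyl chain runs past its floor. Also open, going by these compounds, is how a longer chain or an amine in place of the propyl chain of compound 4 would read in this assay.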